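The compounds below may be only part of what the source reports. "The series", "measured", "known", "first", "only" and "open" are said of these compounds alone.

The measured compounds and their numbers:

Compound 1, `COc1ccc(C2C(C#N)=C(N)N(c3cc(OC)c(OC)c(OC)c3)C3=C2C(=O)CC(C)(C)C3)cc1`, gives 11% in a functional assay on Ehrlich cells (Mus musculus) for cytotoxicity, tested at 50 ug/mL; on this read-out higher numbers stand for a stronger effect at the one concentration tested and lower numbers for a weaker effect.
Compound 2, `COc1cc(N2C(N)=C(C#N)C(c3c(OC)ccc4ccccc34)C3=C2CC(C)(C)CC3=O)cc(OC)c1OC`, gives 10%.
Compound 3, `COc1cc(N2C(N)=C(C#N)C(c3ccccc3O)C3=C2CC(C)(C)CC3=O)cc(OC)c1OC`, gives 2%.

All three share one core and differ only in the aromatic group attached to a saturated ring carbon. Compound 3 has the smallest of the three numbers, but it is not set apart from the others: a number 9 percentage points lower from compound 1 to compound 3 (within the scatter) and a number 8 percentage points lower from compound 2 to compound 3 (within the scatter), both within the usual scatter of this kind of measurement.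

Compound 4, `COc1cc(N2C(N)=C(C#N)C(c3c(O)ccc4ccccc34)C3=C2CC(C)(C)CC3=O)cc(OC)c1OC`, is obtained from compound 3 by 2-hydroxynaphthalen-1-yl in place of 2-hydroxyphenyl on a saturated ring carbon. Going by the values given here, the one measured step that resembles this change is the move from 4-methoxyphenyl to 2-methoxynaphthalen-1-yl, going from one six-membered aromatic ring to two while keeping the oxygen substituent, where a number 1 percentage points lower from compound 1 to compound 2 (within the scatter). That step stayed within the scatter, so for compound 4 a change of a number 1 percentage points higher from compound 3 to compound 4 (within the scatter) is expected, none that would stand out from the scatter. Compound 4 is therefore estimated at 3%, within a range from 0% to 12%.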

Compound 4, a percentage reported as activity, at one concentration (the size of the read-out at that concentration, not a potency): 15%
For compound 4 the middle estimate is 12 percentage points below the measured one; the measured number lies above the stated range.
By their numbers in this assay, from the lowest: compounds 3, 2, 1 and 4 (each within the scatter of the next, the first and the last beyond it).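

Going by these compounds alone, at this saturated ring carbon, replacing 2-hydroxyphenyl with 2-hydroxynaphthalen-1-yl gives the first step in this assay that clears the scatter: a number 13 percentage points higher from compound 3 to compound 4 (beyond the scatter). The aromatic group at this position can therefore shift the read-out, though only modestly. The other two changes do not separate their compounds: hydrogen in place of methyl on the oxygen gives a number 5 percentage points higher from compound 2 to compound 4 (within the scatter), and the change from 4-methoxyphenyl gives a number 4 percentage points higher from compound 1 to compound 4 (within the scatter). No experimental evidence is available to explain these results.

On these data alone, it remains open whether an amine or a carboxylic acid in place of the hydroxyl on the 2-hydroxynaphthalen-1-yl group would keep, raise or lower the number. As far as these compounds go, every number here also comes from a single concentration, so how potency varies across these compounds remains unknown.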